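Lengthening the chain of compound 2

The compounds below may be only part of what the source reports. "The series", "measured", "known", "first", "only" and "open" are said of these compounds alone.

Measured in a functional assay on A549 cells (Homo sapiens) for antiproliferative activity, read by MTT assay, with a stated time of 72 h; a lower number here means a stronger inhibitor, a higher number a weaker inhibitor:
compound 1 `CCCCCCCNC[C@@H]1OC[C@H](N)[C@@H]1O` gives > 128000 nM
compound 2 `CCCCCCCNC[C@@H]1OC[C@H](N)[C@H]1O` gives > 128000 nM

Compound 2 stands at a limit of this assay and has no numerical reading: it gives > 128000 nM as a limit. Compound 1 gives > 128000 nM as a limit too. Among the compounds with values here, the only measured step is a step that the two limits leave unreadable from compound 1 to compound 2 and it concerns (the fact that compounds 1 and 2 differ only in the configuration as drawn), so it offers no size to scale from and does not touch the chain.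

Compound 3 `CCCCCCCCCCNC[C@@H]1OC[C@H](N)[C@H]1O` keeps the configuration of compound 2 and differs from it by propyl in place of hydrogen on a saturated chain carbon, seven bonds along the chain from an amine nitrogen in the chain. With compound 2 at the limit of > 128000 nM, a readable result can only lie on the stronger side. A moderate gain is therefore expected, though a second limit remains quite possible. The estimated change is an at least 3.2-fold lower number from compound 2 to compound 3 (0.50 log units; beyond the scatter) in this assay. Compound 3 is expected at 40000 nM, with an estimated range from 12000 nM to 128000 nM.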

Compound 3, half-maximal inhibitory concentration: > 128000 nM
Compound 3: no number, only a limit (the forecaster's own chance of this, stated with the estimate: 30%); middle value at least 3.2-fold (0.50 log units) away from the limit.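

Compound 2 and compound 3 both stand at a limit in this assay, so the step between them cannot be read: the limit of > 128000 nM in this assay, at which 3 of the 3 values shown sit.

The compounds shown leave open whether any chain on the shared core gives a numerical reading in this assay, and whether the configuration as drawn would then matter.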